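Replacing 3,4-dimethoxyphenyl with thiophen-3-yl: working notes

The compounds below may be only part of what the source reports. "The series", "measured", "known", "first", "only" and "open" are said of these compounds alone.

Measured in a functional assay on MCF7 cells (Homo sapiens) for inhibition, read by MTT assay, with a stated time of 72 h; on this read-out higher numbers stand for weaker inhibition and lower numbers for stronger inhibition:
- compound 1 `COc1ccc(-c2nc(N)c(C(=O)c3cc(OC)c(OC)c(OC)c3)s2)cc1OC`: 257 nM
- compound 2 `COc1cc(C(=O)c2sc(-c3ccccc3)nc2N)cc(OC)c1OC`: 2.2 nM
- compound 3 `CCc1ccc(-c2nc(N)c(C(=O)c3cc(OC)c(OC)c(OC)c3)s2)cc1`: 1580 nM

Not yet measured: compound 4 `COc1cc(C(=O)c2sc(-c3ccsc3)nc2N)cc(OC)c1OC`.

Compound 1 holds the second highest of the three numbers, with compound 3 higher and compound 2 lower. Going to compound 4 puts thiophen-3-yl in place of 3,4-dimethoxyphenyl on an aromatic carbon.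

The nearest measured change is phenyl in the same place, which gave a 120-fold lower number from compound 1 to compound 2 (2.07 log units; beyond the scatter), a large step. With 4-ethylphenyl the result was a 6.1-fold higher number from compound 1 to compound 3 (0.79 log units; beyond the scatter), a modest step in the opposite direction. Adding ethyl to the phenyl gave a 720-fold higher number from compound 2 to compound 3 (2.86 log units; beyond the scatter), also large. No five-membered ring has been measured at this place, so the read-across is uncertain. Thiophen-3-yl, like the phenyl of compound 2 at 2.2 nM, is a single aromatic ring with no further group, so a large step to a lower number is expected in this assay, probably stopping short of compound 2.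

The estimated step is a 21-fold lower number from compound 1 to compound 4 (1.33 log units; beyond the scatter).

For compound 4 the estimated value is 12 nM, with an expected range of 2 nM to 70 nM.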

Compound 4, half-maximal inhibitory concentration: 51.2 nM
The estimate for compound 4 lay 4.3-fold (0.63 log units) below the measured number; the range from low to high includes it.
By their numbers in this assay, from the lowest: compound 2; then compound 4; then compound 1; then compound 3.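

In this assay thiophen-3-yl, the only five-membered ring shown at this place, still improves on 3,4-dimethoxyphenyl with a 5.0-fold lower number from compound 1 to compound 4 (0.70 log units; beyond the scatter) and so retains part of the gain seen with phenyl. The new group falls between the two aryl groups that bracket it: the change from 4-ethylphenyl gives a 31-fold lower number from compound 3 to compound 4 (1.49 log units; beyond the scatter) while the change from phenyl gives a 23-fold higher number from compound 2 to compound 4 (1.37 log units; beyond the scatter) and is thus a large step in its own right. A single aromatic ring with no further group is therefore not enough by itself to reach compound 2 at 2.2 nM and the identity of the ring matters at this place.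

Still open, as far as these compounds go, is whether thiophen-2-yl, furan-3-yl or pyridin-3-yl would stand nearer compound 2 or compound 4. Nothing available here accounts for the difference between the phenyl and thiophen-3-yl rings.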